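The source may hold more compounds than are shown below. What is called first, only, known or untested is meant among the compounds shown, and "the series" means these compounds.

Compound 1, `O=C(/C=C\c1cccc(O)c1)N1N=C(c2ccncc2)OC1c1c[nH]c2ccccc12`, stands only at a limit on the numbers shown: in an ADME assay on HeLa cells (Homo sapiens) for cytotoxicity, read by MTT assay, with a stated time of 72 h (a lower number here means a stronger inhibitor of growth, a higher number a weaker inhibitor of growth), compound 1 gives > 30 ug/mL, which is a limit of the assay and not a number. Compound 2, `O=C(/C=C\c1ccc(O)cc1)N1N=C(c2ccncc2)OC1c1c[nH]c2ccccc12`, differs from it by 4-hydroxyphenyl in place of 3-hydroxyphenyl on a double-bonded chain carbon bound to a double-bonded chain carbon. In this assay compound 2 gives > 30 ug/mL, again a limit. For the measured compounds named here, the single measured step, a step that the two limits leave unreadable from compound 1 to compound 2, is thus unreadable in size, and the limit of > 30 ug/mL in this assay, at which 2 of the 2 values shown sit, holds both values. Compound 3, `O=C(/C=C\c1cccc(Cl)c1Cl)N1N=C(c2ccncc2)OC1c1c[nH]c2ccccc12`, is the compound still to be measured. Its change from compound 1 is 2,3-dichlorophenyl in place of 3-hydroxyphenyl on a double-bonded chain carbon bound to a double-bonded chain carbon. Going by the values given here, no measured step follows a hydroxyphenyl giving way to a dichlorophenyl, so no direction beyond the scatter can be read from what is known. The step is estimated as a number no higher from compound 1 to compound 3 (the limit leaves the size open). Compound 3 is expected to give about 30 ug/mL in this assay, likely between 8 ug/mL and 80 ug/mL, with a fair chance that only a limit is reported.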

Compound 3, concentration for 50% growth inhibition: > 30 ug/mL
Compound 3: only a limit was reported; the forecaster's own chance of this, stated with the estimate: 55%; the middle value lies on the limit itself.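

In this assay compound 3 gives > 30 ug/mL, a limit of the assay and not a number, so the steps to it from compound 1 and compound 2 cannot be read. The compounds shown leave open how these three compare in growth inhibition: the limit of > 30 ug/mL in this assay, at which 3 of the 3 values shown sit.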